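Swapping tert-butyl for trifluoromethoxy on a bile acid receptor ligand

This account rests on a few compounds, and the source may have more. Where it says the series, first, only, none or still open, it means among the compounds named here.

Measured compounds:
Compound 1 `COC(=O)/C=C/c1cccc(N(Cc2ccc(-c3ccc(C(C)(C)C)cc3)cc2)C(=O)C2CCCCC2)c1` gives 132 nM in an assay on isolated protein with Bile acid receptor (Homo sapiens) as the target; a higher number here means that more compound is needed for the effect, a lower number that less compound is needed.
Compound 2 `COC/C=C/c1cccc(N(Cc2ccc(/C=C/C(=O)OC(C)(C)C)cc2)C(=O)C2CCCCC2)c1` gives 243 nM in this assay.

The two values of compound 1 and compound 2 lie within the usual scatter of each other, so neither is placed ahead of the other. Compound 3 `COC(=O)/C=C/c1cccc(N(Cc2ccc(-c3ccc(OC(F)(F)F)cc3)cc2)C(=O)C2CCCCC2)c1` has not yet been measured. It differs from compound 1 by trifluoromethoxy in place of tert-butyl on an aromatic carbon. Among the measured compounds shown here, no step between measured compounds informs this change, so the expectation is a small step, if any, and most likely toward a higher number. The estimated step of a 1.5-fold higher number from compound 1 to compound 3 (0.18 log units; within the scatter) is expected to stay near the scatter. Compound 3 is estimated at 200 nM, with a range from 70 nM to 600 nM.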

Compound 3, half-maximal effective concentration: 264 nM
Beside the measured number, compound 3's estimate is 1.3-fold (0.12 log units) below it; the measured number falls inside the stated range.
By their numbers in this assay, from the lowest: compounds 1, 2 and 3 (each within the scatter of the next).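

Among the compounds shown here, on an aromatic carbon para to a large group, trifluoromethoxy in place of tert-butyl is the first single-place change that can be read. In this assay it appears as a 2.0-fold higher number from compound 1 to compound 3 (0.30 log units; within the scatter) and so does not separate the two groups, which means that on the core of compound 1 this position carries either one within the scatter. No available evidence bears on this result.

From the compounds shown here alone, whether an amine, a carboxylic acid or a longer chain at this position would fall outside the scatter remains open. So does whether the same swap would read alike on the core of compound 2.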